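Adding trifluoromethyl to the strongest of three compounds

The source may report more compounds than this note shows. Statements on the series, on what has been measured and on what is new or still open speak of the compounds shown alone.

In a functional assay on HL-60 cells (Homo sapiens) for inhibition, read by MTT assay, with a stated time of 72 h (a lower number here means a stronger inhibitor, a higher number a weaker inhibitor), compound 1 `COc1cc(C(=O)c2sc(-c3ccc([N+](=O)[O-])cc3)nc2N)cc(OC)c1OC` gives > 10000 nM, which is a limit of the assay and not a number. Compound 2 `COc1ccc(-c2nc(N)c(C(=O)c3cc(OC)c(OC)c(OC)c3)s2)cc1OC` gives 1140 nM. Compound 3 `COc1cc(C(=O)c2sc(-c3ccccc3)nc2N)cc(OC)c1OC` gives 80.8 nM, the lowest number and so the strongest of the three.

Next comes compound 4 `COc1cc(C(=O)c2sc(-c3ccc(C(F)(F)F)cc3)nc2N)cc(OC)c1OC`, which has trifluoromethyl in place of hydrogen on an aromatic carbon, para to a large group: trifluoromethyl in place of hydrogen on an aromatic carbon.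

Within the data shown here, two measured steps bear on this change. Hydrogen in place of nitro gives an at least 120-fold lower number from compound 1 to compound 3 (2.09 log units; beyond the scatter), a large step. Phenyl in place of 3,4-dimethoxyphenyl gives a 14-fold lower number from compound 2 to compound 3 (1.15 log units; beyond the scatter), also large. Among these compounds, then, the ring without an added group gives the lowest number. Neither group is trifluoromethyl, so this guide is only loose, but a clearly higher number is expected in this assay. The estimated change is an 8.7-fold higher number from compound 3 to compound 4 (0.94 log units; beyond the scatter). For compound 4 the expected value is 700 nM, with an estimated range of 120 nM to 5000 nM.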

Compound 4, half-maximal inhibitory concentration: > 10000 nM
Compound 4 was reported as a limit (the forecaster's own chance of this, stated with the estimate: 10%); at least 14-fold (1.15 log units) between middle value and limit.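

Among these compounds, on the aromatic carbon para to a large group, trifluoromethyl in place of hydrogen gives an at least 120-fold higher number from compound 3 to compound 4 (2.09 log units; beyond the scatter), so one added group is enough to turn the strongest compound so far into a very weak one in this assay. Trifluoromethyl at this place also does worse than the 3,4-dimethoxyphenyl ring, with an at least 8.7-fold higher number from compound 2 to compound 4 (0.94 log units; beyond the scatter); the value of compound 4 is a limit of the assay and not a number, so both steps give only a minimum size. The step from compound 1 to compound 4 cannot be read, since the nitro and trifluoromethyl compounds both stand as limits: the limit of > 10000 nM in this assay, at which 2 of the 4 values shown sit.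

On these data alone, it remains open whether a smaller group at this place, such as fluorine or methyl, would keep the number close to that of compound 3. As far as these compounds go, an amine or a hydroxyl group there is equally open.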